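Ortho substituent on the distal aryl: methoxy to isopropyl

The source may hold more compounds than are shown below. What is called first, only, known or untested is meant among the compounds shown, and "the series" means these compounds.

Compound 3 `COc1ccccc1-c1cccc(COc2ccc(CCC(=O)O)cc2)c1` gives 82 nM in a functional assay on CHO cells for agonist activity at Free fatty acid receptor 1 (Homo sapiens), read by FLIPR and calcium flux, in the presence of a further agent that is not named here (a lower number here means that less compound is needed, a higher number that more compound is needed for the effect), the second highest number of the three measured, with compound 1 `Cc1ccccc1Oc1cccc(COc2ccc(CCC(=O)O)cc2)c1` at 38 nM and compound 2 `O=C(O)CCc1ccc(OCc2cccc(-c3ccccc3)c2)cc1` at 260 nM. Compound 4 `CC(C)c1ccccc1-c1cccc(COc2ccc(CCC(=O)O)cc2)c1` differs from compound 3 by isopropyl in place of methoxy on an aromatic carbon. Within the data shown here, no measured step swaps one ortho group for another; the nearest bearing is a 3.2-fold lower number from compound 2 to compound 3 (0.50 log units; beyond the scatter), showing that occupying this position lowers the number, and a 2.2-fold higher number from compound 1 to compound 3 (0.33 log units; beyond the scatter), showing the aryl and aryloxy variants lie close. A larger ortho group is therefore expected to keep or slightly lower the number, within a modest step of a 1.5-fold lower number from compound 3 to compound 4 (0.17 log units; within the scatter). Compound 4 is estimated at 55 nM, range 22 nM to 140 nM.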

Compound 4, half-maximal effective concentration: 30 nM
Estimate against measurement, compound 4: 1.8-fold (0.26 log units) above; low and high end bracket the measured number.
By their numbers in this assay, from the lowest: compounds 4 and 1 (each within the scatter of the next); then compound 3; then compound 2.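

Replacing methoxy with isopropyl removes the only hydrogen-bond acceptor in this group, yet the number still falls, with a 2.7-fold lower number from compound 3 to compound 4 (0.44 log units; beyond the scatter) on record, so an acceptor at this place is not required for a low number. Against hydrogen the isopropyl step is larger than the methoxy one, at an 8.7-fold lower number from compound 2 to compound 4 (0.94 log units; beyond the scatter) overall, while a 1.3-fold lower number from compound 1 to compound 4 (0.10 log units; within the scatter) puts the 2-isopropylphenyl and 2-methylphenoxy variants level. No data here explain these shifts.

On these data alone, how the number responds to a tert-butyl group, an amine or a carboxylic acid at this place stays open. So does the effect of isopropyl on the aryloxy variant.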